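The source may report more compounds than this note shows. Statements on the series, on what has been measured and on what is new or still open speak of the compounds shown alone.

Compound 1, with the structure `COc1cc(-c2cc(/C=C/C(=O)c3ccc(N)cc3)[nH]n2)cc(OC)c1OC`, is one of three compounds in this set that share a core and differ in the groups carried at either end of it. In a functional assay on TK-10 cells (Homo sapiens) for inhibition, read by sulforhodamine B assay, with a stated time of 48 h (on this read-out higher numbers stand for weaker inhibition of growth and lower numbers for stronger inhibition of growth), compound 1 gives 4840 nM, the highest of the three numbers recorded. Compound 2, `COc1ccc(-c2cc(/C=C/C(=O)c3ccc(OC)c(OC)c3)[nH]n2)cc1`, gives 2110 nM in this assay, and compound 3, `COc1ccc(-c2cc(/C=C/C(=O)c3ccc(N)cc3)[nH]n2)cc1OC`, gives 1090 nM. Among the measured compounds shown here, the one step that can be isolated is a 4.4-fold lower number from compound 1 to compound 3 (0.65 log units; beyond the scatter); it concerns the trimethoxyphenyl end of the molecule and not the end attached to the carbonyl carbon.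

Compound 4, `COc1cc(-c2cc(/C=C/C(=O)c3ccc(F)c(F)c3)[nH]n2)cc(OC)c1OC`, is not yet measured in this assay. It differs from compound 1 by 3,4-difluorophenyl in place of 4-aminophenyl on a carbonyl carbon. For the measured compounds named here, no measured pair isolates a change at this position: compound 2 carries a different group on the carbonyl carbon but also differs at the other end, so its value next to that of compound 1 cannot be assigned to either change alone. The data therefore give no direct guide to the size or direction of the step. A step in this assay from compound 1 to compound 4 of about a 1.9-fold lower number from compound 1 to compound 4 (0.29 log units; within the scatter) is expected, with wide uncertainty. Compound 4 is estimated to give 2500 nM in this assay, within a range from 700 nM to 9000 nM.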

Compound 4, concentration for 50% growth inhibition: 2290 nM
Estimate against measurement, compound 4: 1.1-fold (0.04 log units) above, within the range that was stated.
By their numbers in this assay, from the lowest: compounds 3, 2 and 4 (each within the scatter of the next, the first and the last beyond it); then compound 1.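

Among the compounds shown here, compound 4 gives the first reading of a change on the carbonyl carbon with the other end of the molecule held fixed: 3,4-difluorophenyl in place of 4-aminophenyl gives a 2.1-fold lower number from compound 1 to compound 4 (0.33 log units; beyond the scatter) in this assay as a modest step, beyond the scatter. With the trimethoxyphenyl end in place, inhibition of growth therefore does not depend on the 4-aminophenyl group with its hydrogen-bond donor and acceptor, and it is somewhat stronger with a group that has neither. No measurement at hand says why the step has this direction or this size.

The compounds shown leave open whether a single fluorine, as in a 4-fluorophenyl group, or a plain phenyl or 4-hydroxyphenyl group on the carbonyl carbon would give a similar number. They also leave open whether the step would hold with the other end of compound 3 in place of the trimethoxyphenyl end, as no pair shown changes the group on the carbonyl carbon with that end fixed.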